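Swapping a Propyl Tail for Benzyl on the Pyrazole

A few compounds are considered here, and "the series" means these few. Any claim that something is new, unique, unknown or untested is made for them only; others in the source may bear on it.

Of the compounds shown here, two have been measured in an assay on cells for inhibition of protein deacetylase HDAC6 (Homo sapiens), read by fluorescence, with stated times of 15 min and 60 min; on this read-out higher numbers stand for weaker inhibition and lower numbers for stronger inhibition. Compound 1 `CCCc1cc(-c2ccc(F)cc2)nn1Cc1ccc(C(=O)NO)cc1` gives 107 nM in this assay, the higher of the two numbers. Among the measured compounds shown here, compound 2 `O=C(CCCCCNC(=O)c1cc(-c2ccc(F)cc2)[nH]n1)NO` gives 29 nM in this assay, a lower number whose gap to compound 1 lies beyond the usual scatter; the two structures differ in several places at once, so the pair shows only these two values and no single step.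

Compound 3 `O=C(NO)c1ccc(Cn2nc(-c3ccc(F)cc3)cc2Cc2ccccc2)cc1` is the next compound, as yet unmeasured in this assay. It differs from compound 1 in one place: phenyl in place of ethyl on a saturated chain carbon bound to an aromatic carbon, which viewed one bond further out reads propyl to benzyl. For the measured compounds named here, nothing measured so far speaks to this change, so the step is expected to be small, within the scatter, and its direction is uncertain. In this assay compound 3 is expected to give 80 nM, within 30 nM to 250 nM, a change of a 1.3-fold lower number from compound 1 to compound 3 (0.13 log units; within the scatter).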

Compound 3, half-maximal inhibitory concentration: 326 nM
The estimate for compound 3 lay 4.1-fold (0.61 log units) below the measured number; the measured number lies above the stated range.
By their numbers in this assay, from the lowest: compound 2; then compound 1; then compound 3.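

This position is not indifferent to what it carries: in this assay, phenyl in place of ethyl on a saturated chain carbon bound to an aromatic carbon brings a 3.0-fold higher number from compound 1 to compound 3 (0.48 log units; beyond the scatter). On this read-out a higher number means weaker inhibition, so the propyl to benzyl change, which adds one six-membered aromatic ring of carbon only and no hydrogen-bond donors or acceptors, costs a modest amount of inhibition on this core. No measurement at hand gives a reason for the rise.

Going by these compounds, it remains open whether a methyl group, or a chain ending in an amine or a carboxylic acid, would give a lower number than compound 1 does. A single step also cannot show whether cyclohexyl or pyridyl would raise the number as phenyl does.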